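A few compounds are considered here, and "the series" means these few. Any claim that something is new, unique, unknown or untested is made for them only; others in the source may bear on it.

Compound 1 `Nc1ncnc2c1nc(NCc1ccc(Cl)c(Cl)c1)n2[C@@H]1O[C@H](CO)[C@@H](O)[C@H]1O`: 26000 nM
Compound 2 `N#Cc1ccc(COC[C@H]2O[C@@H](n3c(NCc4ccc(Cl)c(Cl)c4)nc4c(N)ncnc43)[C@H](O)[C@@H]2O)cc1`: 5000 nM

In a functional assay on HCT-116 cells (Homo sapiens) for cytotoxicity, read by sulforhodamine B assay (a lower number here means a stronger inhibitor of growth, a higher number a weaker inhibitor of growth), compound 2 holds the lower of the two numbers, at 5000 nM, while compound 1 gives 26000 nM. Compound 3 `COC[C@H]1O[C@@H](n2c(NCc3ccc(Cl)c(Cl)c3)nc3c(N)ncnc32)[C@H](O)[C@@H]1O` departs from compound 2 by hydrogen in place of 4-cyanophenyl on a saturated chain carbon bound to an oxygen on a saturated carbon, turning 4-cyanobenzyl to methyl. For the measured compounds named here, the one measured step that bears on this is a 5.2-fold lower number from compound 1 to compound 2 (0.72 log units; beyond the scatter), where 4-cyanobenzyl replaced hydrogen on the same oxygen. Losing the 4-cyanophenyl should therefore undo part of that gain. The expected change is a 2.6-fold higher number from compound 2 to compound 3 (0.41 log units; beyond the scatter), towards a higher number. For compound 3 the estimated value is 13000 nM, with an expected range of 5500 nM to 30000 nM.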

Compound 3, concentration for 50% growth inhibition: > 80000 nM
Compound 3: no number, only a limit (the forecaster's own chance of this, stated with the estimate: 10%); at least 6.1-fold (0.78 log units) between middle value and limit.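

Compound 3 gives no number in this assay, only a limit: the limit of > 80000 nM in this assay, at which 1 of the 3 values shown sits. Losing the 4-cyanophenyl gives an at least 16-fold higher number from compound 2 to compound 3 (1.20 log units; beyond the scatter). Capping this oxygen is therefore not enough on its own, since methyl moves the number the opposite way to 4-cyanobenzyl, with an at least 3.0-fold higher number from compound 1 to compound 3 (0.48 log units; beyond the scatter).

The compounds shown leave open whether the gain belongs to the nitrile or to the aromatic ring, which a plain benzyl group on this oxygen would separate. From the compounds shown here alone, how a longer chain such as butyl would read also stays open.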